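The source may hold more compounds than are shown below. What is called first, only, known or untested is meant among the compounds shown, and "the series" means these compounds.

Measured in a functional assay on A549 cells (Homo sapiens) for antiproliferative activity, read by sulforhodamine B assay, with a stated time of 3 days; on this read-out higher numbers stand for weaker inhibition of growth and lower numbers for stronger inhibition of growth:
- Compound 1 `O=C(Nc1nccs1)c1cccc(Nc2ncc(F)c(Nc3ccc(F)cc3)n2)c1`: > 10000 nM
- Compound 2 `O=C(c1cccc(Nc2ncc(F)c(Nc3ccc(F)cc3)n2)c1)N1CCCCC1`: 13200 nM

The entry for compound 1, > 10000 nM, is a limit of the assay and not a number. Going by the values given here, compound 2, at 13200 nM, therefore holds the only true number so far in this assay.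

Compound 3 `CN1CCC(C(=O)Nc2cccc(Nc3ncc(F)c(Nc4ccc(F)cc4)n3)c2)CC1`, not yet measured, carries ((1-methylpiperidin-4-yl)carbonyl)amino in place of (piperidin-1-yl)carbonyl on an aromatic carbon.

Among the compounds with values here, only one measured step bears on this change: a step that the limit leaves unreadable from compound 1 to compound 2. It gives no size, and it concerns a different exchange on the carbonyl carbon. The evidence amounts to the limit of > 10000 nM in this assay, at which 1 of the 2 values shown sits, so it supports no direction, and no shift beyond the usual scatter is expected. The expected step is a 1.3-fold lower number from compound 2 to compound 3 (0.12 log units; within the scatter). Compound 3 is estimated at 10000 nM, with an expected range of 2500 nM to 30000 nM.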

Compound 3, concentration for 50% growth inhibition: 1330 nM
Compound 3: the middle estimate sits 7.5-fold (0.88 log units) above what was measured; measured number outside the range, below it.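

On this aromatic carbon, this assay now gives a step that can be read: ((1-methylpiperidin-4-yl)carbonyl)amino in place of (piperidin-1-yl)carbonyl yields a 9.9-fold lower number from compound 2 to compound 3 (1.00 log units; beyond the scatter). The same group in place of (1,3-thiazol-2-yl)carbamoyl yields an at least 7.5-fold lower number from compound 1 to compound 3 (0.87 log units; beyond the scatter). Compound 1 holds a limit and not a number, so this second step marks only a bound and not a true size: the limit of > 10000 nM in this assay, at which 1 of the 3 values shown sits.

The compounds shown leave open whether the first step goes with the amide hydrogen or with the ring nitrogen carrying its methyl group, as both enter in a single change. As far as these compounds go, it also remains open how the value would move with a plain cyclohexyl ring or a morpholine ring in place of the 1-methylpiperidin-4-yl ring on the same carbonyl.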